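Amide variation on a shared core

The source may report more compounds than this note shows. Statements on the series, on what has been measured and on what is new or still open speak of the compounds shown alone.

Compound 1 `CCN(CC)S(=O)(=O)c1ccc(S(=O)(=O)N2CCC[C@@H](C(=O)N3CCC(OC)CC3)C2)cc1`: in a functional assay on MIA PaCa-2 cells (Homo sapiens) for inhibition, read by MTT assay, with a stated time of 3 days (a lower number here means a stronger inhibitor, a higher number a weaker inhibitor), compound 1 gives a limit of > 10000 nM.
Compound 2 `CCN(CC)S(=O)(=O)c1ccc(S(=O)(=O)N2CCC[C@@H](C(=O)N3CCS(=O)(=O)CC3)C2)cc1`: in this assay compound 2 gives a limit of > 10000 nM.

Both values are limits, as the limit of > 10000 nM in this assay, at which 2 of the 2 values shown sit, shows, so the step that the two limits leave unreadable from compound 1 to compound 2 cannot be sized. Compound 2 therefore stands only at a limit, with no number beneath it. Compound 3 `CCN(CC)S(=O)(=O)c1ccc(S(=O)(=O)N2CCC[C@@H](C(=O)N3CC[C@H](OC)C3)C2)cc1` differs by 3-methoxypyrrolidin-1-yl in place of 1,1-dioxothiomorpholin-4-yl on a carbonyl carbon. For the measured compounds named here, no measured step bears on this change; the one step from compound 1 to compound 2 is unreadable. Compound 3 is expected to remain near the limit, with an estimated 15000 nM (range 4000 nM to 60000 nM). The expected step that the limit leaves unreadable from compound 2 to compound 3 is not resolvable beyond the scatter.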

Compound 3, half-maximal inhibitory concentration: > 10000 nM
Compound 3 was reported as a limit; the forecaster's own chance of this, stated with the estimate: 85%; the middle value lies beyond the limit too.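

For the compounds shown here, all three compounds sit at a limit, so no step among compound 1, compound 2 and compound 3 can be read: the limit of > 10000 nM in this assay, at which 3 of the 3 values shown sit.

The compounds shown leave open which amide on the shared core, if any, would give a measurable value in this assay.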